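Methoxy on the aniline of an imidazolyl-thiazole series

The source may hold more compounds than are shown below. What is called first, only, known or untested is meant among the compounds shown, and "the series" means these compounds.

Compound 1 `c1ccc(Nc2nc(-n3ccnc3)cs2)cc1` carries the shared core with a 1H-imidazol-1-yl group. In a functional assay on RKO cells (Homo sapiens) for cytotoxicity, read by resazurin assay, with a stated time of 72 h (a higher number here means a weaker inhibitor, a lower number a stronger inhibitor), compound 1 gives > 100000 nM, which is a limit of the assay and not a number. Compound 2 `Cc1nccn1-c1csc(Nc2ccccc2)n1` differs from compound 1 in one place: hydrogen in place of methyl on an aromatic carbon. In this assay compound 2 gives > 100000 nM, again a limit. The step that the two limits leave unreadable from compound 1 to compound 2 therefore cannot be read. Compound 3 `COc1cccc(Nc2nc(-n3ccnc3C)cs2)c1` adds to compound 2 the change (methoxy in place of hydrogen on an aromatic carbon). In this assay compound 3 gives > 100000 nM, also a limit. The step that the two limits leave unreadable from compound 2 to compound 3 stays unreadable because of the limit of > 100000 nM in this assay, at which 3 of the 3 values shown sit.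

Compound 4 `COc1ccc(Nc2nc(-n3ccnc3)cs2)cc1` has not been measured. It differs from compound 1 by methoxy in place of hydrogen on an aromatic carbon. This is the same kind of change as that from compound 2 to compound 3, but not the same: in compound 4 the methoxy sits para to a large group, in compound 3 meta to a large group, and the two cores differ as already told. In this assay compound 4 is expected to give about 150000 nM, between 50000 nM and 500000 nM, most probably again as a limit. The expected step that the limit leaves unreadable from compound 1 to compound 4, set beside a step that the two limits leave unreadable from compound 2 to compound 3, rests only on (the limit of > 100000 nM in this assay, at which 3 of the 3 values shown sit).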

Compound 4, half-maximal inhibitory concentration: > 100000 nM
Compound 4 gave a limit, no number; the forecaster's own chance of this, stated with the estimate: 85%; the middle value lies beyond the limit too.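

In this assay compound 4 gives a limit and not a number, as compound 1 does, so no new step can be read from compound 1 to compound 4: the limit of > 100000 nM in this assay, at which 4 of the 4 values shown sit.

The compounds shown leave open what size of effect, if any, methoxy in place of hydrogen has in this assay, and which change to the shared core would give a number there.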